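Amide Partner Lifts Inhibition; Ring Swap Tested Again

This account rests on a few compounds, and the source may have more. Where it says the series, first, only, none or still open, it means among the compounds named here.

Measured compounds in a functional assay on Raji cells (Homo sapiens) for antiproliferative activity, read by CCK-8 assay, with a stated time of 72 h, tested at 40 uM; a higher number here means more inhibition at the concentration tested (going by the name of the read-out), a lower number less inhibition:
compound 1 `CCOC(=O)c1sc(-c2cccc(NC(=O)c3ccc(F)c(Cl)c3)c2)nc1Nc1ccc(N2CCN(C)CC2)cc1` gives 20.7%
compound 2 `CCOC(=O)c1sc(-c2cccc(NC(=O)c3ccc(C(F)(F)F)cn3)c2)nc1Nc1ccc(N2CCN(C)CC2)cc1` gives 20.8%
compound 3 `CN1CCN(c2ccc(Nc3nc(-c4cccc(NC(=O)c5ccc(F)c(Cl)c5)c4)sc3C(N)=O)cc2)CC1` gives 94.4%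

Compound 1 and compound 2 share a core and differ only by 5-(trifluoromethyl)pyridin-2-yl in place of 3-chloro-4-fluorophenyl on a carbonyl carbon. In this assay that change made a step of a number 0.1 percentage points higher from compound 1 to compound 2 (within the scatter), so the two compounds cannot be told apart by this measurement.

Compound 3 differs from compound 1 by amino in place of ethoxy on a carbonyl carbon. That change made a step of a number 73.7 percentage points higher from compound 1 to compound 3 (beyond the scatter), which is by far the largest difference among the three measured compounds. Compound 3 stands clearly above both compound 1 and compound 2 in this assay.

Compound 4 `CN1CCN(c2ccc(Nc3nc(-c4cccc(NC(=O)c5ccc(C(F)(F)F)cn5)c4)sc3C(N)=O)cc2)CC1` is not yet measured. It differs from compound 3 by 5-(trifluoromethyl)pyridin-2-yl in place of 3-chloro-4-fluorophenyl on a carbonyl carbon. Within the data shown here, this is the same change as the one from compound 1 to compound 2, made on the same place, with the core of compound 3 carrying the carbamoyl group instead of the ethoxycarbonyl group of compound 1.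

For compound 4 in this assay the expected step is a number 2.4 percentage points lower from compound 3 to compound 4 (within the scatter), resting on the finding that the same change gave a number 0.1 percentage points higher from compound 1 to compound 2 (within the scatter) on the other core. The estimate is tempered because compound 3 already reads 94.4%, leaving little room upward. Compound 4 is therefore expected to give 92%, with a range from 75% to 99%.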

Compound 4, a percentage reported as inhibition, at one concentration (the size of the read-out at that concentration, not a potency): 84.6%
Estimate against measurement, compound 4: 7.4 percentage points above, and the stated range covers the measured number.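

In this assay, placing 5-(trifluoromethyl)pyridin-2-yl where 3-chloro-4-fluorophenyl stood on the carbonyl carbon made a step of a number 9.8 percentage points lower from compound 3 to compound 4 (within the scatter), so this ring swap cannot be told from no change on the core carrying the carbamoyl group, and the comparison with the ethoxycarbonyl core shows that it carried over with no measurable difference: the same change on two cores in this assay, a number 0.1 percentage points higher (within the scatter) from compound 1 to compound 2 and a number 9.8 percentage points lower (within the scatter) from compound 3 to compound 4, 9.9 percentage points apart, within the scatter of two such steps

The other change also carried over, since amino in place of ethoxy made a step of a number 63.8 percentage points higher from compound 2 to compound 4 (beyond the scatter), and this large gain appears with both amide partners, at a size that agrees with the earlier step: the same change on two cores in this assay, a number 73.7 percentage points higher (beyond the scatter) from compound 1 to compound 3 and a number 63.8 percentage points higher (beyond the scatter) from compound 2 to compound 4, 9.9 percentage points apart, within the scatter of two such steps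

Among these compounds, this does not show that the ring swap has no effect at all, only that a reading at one concentration cannot separate the pairs, and two cores and two groups at each place give no general rule for the series.

The compounds shown leave open whether a carboxylic acid or a methylamide on that carbonyl carbon would behave like the amino or the ethoxy compounds. They also leave open whether a plain phenyl or a cyclohexyl as the amide partner would fit the same picture.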